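Chloro removal on the benzylidene aryl of the nitrophenyl analogue

This account rests on a few compounds, and the source may have more. Where it says the series, first, only, none or still open, it means among the compounds named here.

Of the compounds shown here, two carry a number so far. Compound 1 `CC1=C(C(=O)Nc2ccc(F)cc2)C(c2ccc(Br)cc2)n2c(s/c(=C/c3ccc(Cl)cc3)c2=O)=N1` was tested in a functional assay on the whole organism (strain albino) for inhibition, with Rattus norvegicus as the target, read by paw edema, with stated times of 1 h and 3 h, at a dose of 25 mg/kg by the oral route; a higher number here means more inhibition at the dose given (going by the name of the read-out), a lower number less inhibition; in this assay compound 1 gives 25%. Among the measured compounds shown here, compound 2 `CC1=C(C(=O)Nc2ccc(F)cc2)C(c2ccc([N+](=O)[O-])cc2)n2c(s/c(=C/c3ccc(Cl)cc3Cl)c2=O)=N1` differs from compound 1 in two places at once, so no single step connects them; in this assay compound 2 gives 17%. Where compound 2 stands: its number and that of compound 1 lie within the usual scatter of each other, so nothing separates them.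

Compound 3 `CC1=C(C(=O)Nc2ccc(F)cc2)C(c2ccc([N+](=O)[O-])cc2)n2c(s/c(=C/c3ccc(Cl)cc3)c2=O)=N1` is the next member: hydrogen in place of chloro on an aromatic carbon. For the measured compounds named here, no measured step of this kind exists, so the size of the change cannot be read off a neighbour pair. Compound 3 keeps the 4-chlorophenyl group seen in compound 1 together with the nitrophenyl group of compound 2. The step from compound 2 to compound 3 is expected to be a number 3 percentage points higher from compound 2 to compound 3 (within the scatter), a small move that stays inside the scatter. Compound 3 is therefore estimated at 20%, with a range from 8% to 32%.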

Compound 3, a percentage reported as inhibition, in the whole organism at one dose (the size of the read-out at that dose, not a potency): 23%
Beside the measured number, compound 3's estimate is 3 percentage points below it; the range from low to high includes it.
By their numbers in this assay, from the lowest: compounds 2, 3 and 1 (each within the scatter of the next).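

In this assay, two single-place steps can now be read: a number 6 percentage points higher from compound 2 to compound 3 (within the scatter) for 2,4-dichlorophenyl to 4-chlorophenyl, and a number 2 percentage points lower from compound 1 to compound 3 (within the scatter) for nitro in place of bromo on an aromatic carbon. Both steps lie within the scatter, so at this dose neither change separates the compounds, something the earlier pair, which differed in two places at once, could not show. No independent data bear on either step.

The compounds shown leave open whether a group of another kind on this aromatic ring, such as an amine or a carboxylic acid, would give a step beyond the scatter. They also leave open what the loss of the remaining chloro would do.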